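A few compounds are considered here, and "the series" means these few. Any claim that something is new, unique, unknown or untested is made for them only; others in the source may bear on it.

Measured so far:
compound 1, `CC(C)C1=CC2=C(C(=O)C1=O)[C@]13CO[C@H]2C[C@H]1C(C)(C)C[C@H](O)C3`: > 10000 nM
compound 2, `CC(C)C1=C[C@@]23Oc4c(C(C)C)cc5c(c4O[C@]2(C(=O)C1=O)[C@]12CO[C@@H]3C[C@H]1C(C)(C)C[C@H](O)C2)[C@]12CO[C@@H]5C[C@H]1C(C)(C)C[C@H](O)C2`: > 10000 nM

In a functional assay on BGC-823 cells (Homo sapiens) for cytotoxicity, read by MTT assay (a higher number here means a weaker inhibitor, a lower number a stronger inhibitor), compound 1 gives > 10000 nM, which is a limit of the assay rather than a number. In this assay compound 2 likewise gives > 10000 nM, again a limit and not a number. Among the measured compounds shown here, compound 2 therefore stands at the limit of > 10000 nM in this assay, at which 2 of the 2 values shown sit, and no step between measured compounds exists to show how far beyond that limit either compound might sit.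

Compound 3, `CC(C)C1=C[C@]23Oc4c(C(C)C)cc5c(c4O[C@@]2(C(=O)C1=O)[C@]12CO[C@@H]3C[C@H]1C(C)(C)C[C@H](O)C2)[C@]12CO[C@@H]5C[C@H]1C(C)(C)C[C@H](O)C2`, is not yet measured. Relative to compound 2 the change is the two compounds have the same atoms and bonds and differ only in configuration as drawn: 2 of 10 stereo elements differ; a stereocentre at a saturated ring carbon is drawn S in compound 2 and R in compound 3; a stereocentre at a saturated ring carbon is drawn R in compound 2 and S in compound 3. For the measured compounds named here, with only configuration altered and both measured compounds at the limit, there is no measured step to draw on. The step that the limit leaves unreadable from compound 2 to compound 3 is expected to be none beyond the scatter, with the most probable outcome again a limit. For compound 3 the estimate in this assay is 15000 nM, within 5000 nM to 50000 nM.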

Compound 3, half-maximal inhibitory concentration: 4800 nM
Estimate against measurement, compound 3: 3.1-fold (0.49 log units) above; the whole stated range lies above it.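

In this assay the series now has a readable number, and reversing two stereocentres at saturated ring carbons gives an at least 2.0-fold lower number from compound 2 to compound 3 (0.31 log units; beyond the scatter). Compound 2 gives only a limit, so this step has a lower bound and no measured size. While all earlier values sat at the limit, nothing showed that any change could register in this read-out; here the shift goes with configuration alone, with no group entering or leaving: the fact that compounds 2 and 3 differ only in the configuration as drawn

From the compounds shown here alone, whether one of the two stereocentres alone carries the step remains open, as does how far compound 2 lies beyond its limit. Also open, going by these compounds, is whether an amine or a carboxylic acid in place of the hydroxyl groups, on this same configuration, would move the number in this assay any further.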